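The source may hold more compounds than are shown below. What is called first, only, known or untested is meant among the compounds shown, and "the series" means these compounds.

In a functional assay on PC-12 cells (Rattus norvegicus) for cytotoxicity, read by MTT assay, with stated times of 2 h and 24 h, tested at 5 uM (on this read-out lower numbers stand for a weaker effect and higher numbers for a stronger effect at the one concentration tested), compound 1 `CC(C)c1ccc(-n2nc(-c3ccc(C(F)(F)F)cc3O)nc2-c2ccccc2O)cc1` gives 100%. Compound 2 `Oc1cc(C(F)(F)F)ccc1-c1nc(-c2ccccc2O)n(-c2ccc(I)cc2)n1` gives 94.4% in this assay and so stands close beside compound 1, the step of a number 5.6 percentage points lower from compound 1 to compound 2 (within the scatter) lying within the scatter. Compound 3 `Oc1cc(C(F)(F)F)ccc1-c1nc(-c2ccccc2O)n(-c2ccccc2F)n1` differs from compound 2 by 2-fluorophenyl in place of 4-iodophenyl on an aromatic nitrogen. Within the data shown here, the one measured step, a number 5.6 percentage points lower from compound 1 to compound 2 (within the scatter), also exchanged the group on an aromatic nitrogen and barely moved the read-out, so the expected step of a number 2.4 percentage points lower from compound 2 to compound 3 (within the scatter) is none beyond the scatter. Compound 3 is estimated to give about 92% in this assay, within a range from 78% to 100%.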

Compound 3, a percentage reported as activity, at one concentration (the size of the read-out at that concentration, not a potency): 86.6%
The estimate for compound 3 lay 5.4 percentage points above the measured number, within the range that was stated.
By their numbers in this assay, from the lowest: compounds 3, 2 and 1 (each within the scatter of the next, the first and the last beyond it).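

In this assay, the group on this aromatic nitrogen now shows a first, small influence, with 2-fluorophenyl in place of 4-isopropylphenyl giving a number 13.4 percentage points lower from compound 1 to compound 3 (beyond the scatter) on the read-out. Against 4-iodophenyl, the same group gives a number 7.8 percentage points lower from compound 2 to compound 3 (within the scatter) and cannot be told apart from it. Nothing available here accounts for the change.

The exchange from 4-iodophenyl to 2-fluorophenyl alters both the halogen and its place on the ring, and these compounds cannot separate the two. On these data alone, whether this nitrogen tolerates an amine-bearing phenyl group or a simple methyl also stays open.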